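The source may hold more compounds than are shown below. What is called first, only, known or untested is meant among the compounds shown, and "the series" means these compounds.

Measured compounds:
compound 1, `O=[N+]([O-])c1cccc(-c2nn(-c3ccccc3)cc2C(Nc2nc3ccccc3s2)c2c(O)ccc3ccccc23)c1`; in a functional assay on HeLa cells (Homo sapiens) for antiproliferative activity, read by MTT assay, with a stated time of 48 h (on this read-out higher numbers stand for weaker inhibition and lower numbers for stronger inhibition), compound 1 gives 8220 nM.
compound 2, `COc1ccc2nc(NC(c3cn(-c4ccccc4)nc3-c3cccc([N+](=O)[O-])c3)c3c(O)ccc4ccccc34)sc2c1`; compound 2 gives 6140 nM.
compound 3, `COc1cccc(-c2nn(-c3ccccc3)cc2C(Nc2nc3ccc(OC)cc3s2)c2c(O)ccc3ccccc23)c1`; compound 3 gives 10500 nM.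

Compound 4, `COc1ccc2nc(NC(c3cn(-c4ccccc4)nc3-c3ccccc3)c3c(O)ccc4ccccc34)sc2c1`, is not yet measured. From compound 3 to compound 4 the change is hydrogen in place of methoxy on an aromatic carbon. The same kind of change was made from compound 2 to compound 1, where it is hydrogen in place of methoxy on an aromatic carbon and gave a 1.3-fold higher number from compound 2 to compound 1 (0.13 log units; within the scatter). The surroundings differ: in compound 3 the methoxy sits on a six-membered aromatic ring of carbon only, meta to a large group, whereas in compound 2 it sits on a ring that is part of a fused system of two rings. The cores of compound 2 and compound 3 also differ, by methoxy in place of nitro on an aromatic carbon, which gave a 1.7-fold higher number from compound 2 to compound 3 (0.23 log units; within the scatter). Because the earlier step of a 1.3-fold higher number from compound 2 to compound 1 (0.13 log units; within the scatter) stayed within the scatter, a similarly small step is expected here: a 1.1-fold higher number from compound 3 to compound 4 (0.06 log units; within the scatter). Compound 4 is therefore estimated at 12000 nM, most likely between 6000 nM and 25000 nM.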

Compound 4, half-maximal inhibitory concentration: 8290 nM
Beside the measured number, compound 4's estimate is 1.4-fold (0.16 log units) above it, within the range that was stated.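

In this assay, hydrogen in place of methoxy was tried on two cores, and the two results cannot be told apart: the same change on two cores in this assay, a 1.3-fold higher number (0.13 log units; within the scatter) from compound 2 to compound 1 and a 1.3-fold lower number (0.10 log units; within the scatter) from compound 3 to compound 4, 1.7-fold (0.23 log units) apart, within the scatter of two such steps. The new comparisons are also small, with a 1.3-fold lower number from compound 3 to compound 4 (0.10 log units; within the scatter) and a 1.4-fold higher number from compound 2 to compound 4 (0.13 log units; within the scatter). So this change carries from one core to the other without a detectable difference, but two steps this small do not show that it has any real effect, or that it would behave alike on other cores.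

The compounds shown leave open whether another group in the same place, such as an amine, a carboxylic acid or a longer chain, would move the number beyond the scatter.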